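Fluoro to chloro on the aryl terminus: compound 4

The compounds below may be only part of what the source reports. "The series", "measured", "known", "first", "only" and "open" are said of these compounds alone.

Values in a functional assay on HeLa cells (Homo sapiens) for inhibition, read by MTT assay, with a stated time of 72 h; a lower number here means a stronger inhibitor, a higher number a weaker inhibitor:
- compound 1 `COc1cc(NC(C)CCCNC(=O)NNC(=O)Nc2ccc(C(F)(F)F)cc2)c2ncccc2c1` gives 15000 nM
- compound 2 `COc1cc(NC(C)CCCNC(=O)Nc2cccc(O)c2)c2ncccc2c1` gives 48000 nM
- compound 3 `COc1cc(NC(C)CCCNC(=O)NNC(=O)Nc2cccc(F)c2)c2ncccc2c1` gives > 250000 nM, which is a limit and not a number
- compound 4 `COc1cc(NC(C)CCCNC(=O)NNC(=O)Nc2cccc(Cl)c2)c2ncccc2c1` has not been measured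

Compound 3 stands at the limit of > 250000 nM in this assay, at which 1 of the 3 values shown sits. Compound 4 carries chloro in place of fluoro on an aromatic carbon, meta to a large group (chloro in place of fluoro on an aromatic carbon).

The closest measured comparison is an at least 16-fold higher number from compound 1 to compound 3 (1.22 log units; beyond the scatter), which also changes only the aryl group and is large. The other, an at least 5.2-fold higher number from compound 2 to compound 3 (0.71 log units; beyond the scatter), is at least modest, but it alters more of the side chain and bears less directly. Going by the values given here, both show only that compound 3 sits on the weak side of this small set. Compound 1 at 15000 nM shows that the aryl group can move the number a long way, so some gain is expected from this single-atom exchange, though a smaller one. The expected change is an at least 2.5-fold lower number from compound 3 to compound 4 (0.39 log units; beyond the scatter), towards a lower number, and a second limit remains possible. For compound 4 the estimated value in this assay is 100000 nM, with an expected range of 25000 nM to 250000 nM.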

Compound 4, half-maximal inhibitory concentration: 44000 nM
Compound 4: the middle estimate sits 2.3-fold (0.36 log units) above what was measured; the range from low to high includes it.
By their numbers in this assay, from the lowest: compound 1; then compounds 4 and 2 (each within the scatter of the next). At a limit, above all of these: compound 3.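

In this assay, chloro in place of fluoro on the aromatic carbon, with no change in ring or in hydrogen-bond donor and acceptor counts, gives an at least 5.6-fold lower number from compound 3 to compound 4 (0.75 log units; beyond the scatter), so this single-atom exchange alone is enough to produce a measurable value in this series. The size of that step is only a lower bound, as compound 3 gives a limit and not a number: the limit of > 250000 nM in this assay, at which 1 of the 4 values shown sits. The other comparisons read a 1.1-fold lower number from compound 2 to compound 4 (0.04 log units; within the scatter), so these two compounds cannot be told apart, and a 2.9-fold higher number from compound 1 to compound 4 (0.47 log units; beyond the scatter), so 3-chlorophenyl does not match 4-(trifluoromethyl)phenyl on this side chain.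

On these data alone, whether bromo or methyl on the same aromatic carbon would extend the step from fluoro to chloro remains open. The comparison of 3-chlorophenyl with 4-(trifluoromethyl)phenyl changes both the group and its place on the ring, so the contribution of each stays unresolved.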